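Cyclic amidine in place of the isopropyl amidine

The source may report more compounds than this note shows. Statements on the series, on what has been measured and on what is new or still open speak of the compounds shown alone.

Among the compounds with values here, compound 2 `CC(C)NC(=N)c1ccc2oc(-c3cccc(OCCCCCOc4ccccc4)c3)cc2c1` gives 10100 nM in an ADME assay on L6 cells (Rattus norvegicus) for cytotoxicity, read by resazurin assay, with a stated time of 70 h (a lower number here means a stronger inhibitor, a higher number a weaker inhibitor), the highest of the two numbers so far; compound 1 `N=C(N)c1ccc2oc(-c3cccc(OCCCCCOc4ccccc4)c3)cc2c1` gives 3000 nM. Within the data shown here, the only step in this region, a 3.4-fold higher number from compound 1 to compound 2 (0.53 log units; beyond the scatter), is modest. Compound 3 `c1ccc(OCCCCCOc2cccc(-c3cc4cc(C5=NCCN5)ccc4o3)c2)cc1` carries a group of 5 heavy atoms (3 carbon, 2 nitrogen; one five-membered non-aromatic ring with 2 hetero atoms) in place of a group of 6 heavy atoms (4 carbon, 2 nitrogen; no ring), on an aromatic carbon. Among the measured compounds shown here, no measured step covers this change; the step from compound 1 to compound 2 only shows that the amidine region moves the number modestly. A step of a 1.7-fold lower number from compound 2 to compound 3 (0.23 log units; within the scatter) toward compound 1 is therefore expected. Compound 3 is estimated at 6000 nM, within 2500 nM to 15000 nM.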

Compound 3, half-maximal inhibitory concentration: 2600 nM
Compound 3: middle estimate off by 2.3-fold (0.36 log units), on the high side, and the stated range covers the measured number.
By their numbers in this assay, from the lowest: compounds 3 and 1 (each within the scatter of the next); then compound 2.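

In this assay, the five-membered non-aromatic ring gives a 3.9-fold lower number from compound 2 to compound 3 (0.59 log units; beyond the scatter) when it replaces the open isopropyl amidine, so carrying a carbon group on the amidine nitrogen does not by itself keep the number high. The ring also gives a 1.2-fold lower number from compound 1 to compound 3 (0.06 log units; within the scatter) against the unsubstituted amidine, so the two cannot be told apart here. Nothing available explains the difference between the ring and the open isopropyl group. Still open, as far as these compounds go, is whether a six-membered cyclic amidine, or a methyl group on the ring nitrogen, would stay level with compound 3.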